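The compounds below may be only part of what the source reports. "The series", "measured", "known", "first", "only" and "open" are said of these compounds alone.

Measured so far:
Compound 1, `Cc1ccc(C(=O)O)cc1OCCCCOc1ccc(C(=O)CC2CCCC2)c(O)c1C`, in an assay on HEK293 cells for positive allosteric modulation of metabotropic glutamate receptor 3 (Rattus norvegicus), read by thallium flux, with a stated time of 2.5 min (a lower number here means that less compound is needed, a higher number that more compound is needed for the effect), reaches only the limit > 10000 nM, a boundary of the measurement rather than a number.
Compound 2, `Cc1c(OCCCCOc2ccc(C(=O)O)c(Cl)c2)ccc(C(=O)CC2CCCC2)c1O`, in this assay gives 2250 nM.

For the measured compounds named here, compound 2 thus holds the only actual number in this assay; the other value shown is a limit, as the limit of > 10000 nM in this assay, at which 1 of the 2 values shown sits, records. Compound 3, `Cc1cc(OCCCCOc2ccc(C(=O)CC3CCCC3)c(O)c2C)ccc1C(=O)O`, has not yet been measured. It differs from compound 2 in one place: methyl in place of chloro on an aromatic carbon. One measured step exists for comparison, an at least 4.4-fold lower number from compound 1 to compound 2 (0.64 log units; beyond the scatter), but that step swaps the whole aryl group on the ether oxygen rather than one substituent, so it bears on the present change only loosely. Going by the values given here, no measured step shows what replacing chloro with methyl does, and the scarcity of numbers leaves room for a surprise in either direction. Among the compounds with values here, compound 3 is therefore expected to stay within the scatter of the one measured number, at an estimated 3000 nM, with a range from 1000 nM to 10000 nM. The expected step is a 1.3-fold higher number from compound 2 to compound 3 (0.12 log units; within the scatter).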

Compound 3, half-maximal effective concentration: > 10000 nM
Compound 3 ended at the assay's limit; the forecaster's own chance of this, stated with the estimate: 25%; middle value at least 3.3-fold (0.52 log units) away from the limit.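

Chloro and methyl each count as 1 heavy atom, with no ring and no net charge, yet exchanging them on the aromatic carbon ortho to the carboxy group gives an at least 4.4-fold higher number from compound 2 to compound 3 (0.64 log units; beyond the scatter). In this assay compound 3 gives > 10000 nM, which is a limit of the assay and not a number. The earlier step replaced one whole aryl group with another, whereas this one keeps the 4-carboxyphenyl arrangement and changes one substituent, so it shows that this position alone can separate a measurable value from the limit, at least for this pair of groups.

For the compounds shown here, the step between compound 1 and compound 3 cannot be read, and the series so far offers only one actual number: the limit of > 10000 nM in this assay, at which 2 of the 3 values shown sit. How far compound 3 lies past the limit remains unknown, as does whether chloro is special at this position or whether a bromo, methoxy or nitrile group there would match compound 2, give a lower number or also end at the limit.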